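Removing the benzyl from the core: compound 3

The source may hold more compounds than are shown below. What is called first, only, known or untested is meant among the compounds shown, and "the series" means these compounds.

Measured so far:
- compound 1, `Nc1n/c(=N\CCCCc2ccccc2)nc(N)c2c1ncn2Cc1ccccc1`: 8800 nM in a functional assay on MCF7 cells (Homo sapiens) for antiproliferative activity, read by WST assay, with a stated time of 72 h; on this read-out lower numbers stand for stronger inhibition and higher numbers for weaker inhibition
- compound 2, `CCCCCCCC/N=c1\nc(N)c2ncn(Cc3ccccc3)c2c(N)n1`: 4550 nM in this assay

Among the compounds with values here, only one step links these two: a 1.9-fold lower number from compound 1 to compound 2 (0.29 log units; within the scatter), and it touches the side chain, not the core. Compound 2 gives the lowest of the two numbers in this assay, with compound 1 the nearest, but the gap between them is within the scatter, so neither can be called the stronger.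

Compound 3, `CCCCCCCC/N=c1\nc(N)c2nc[nH]c2c(N)n1`, differs from compound 2 by hydrogen in place of benzyl on an aromatic nitrogen. No measured step concerns this part of the molecule, so nothing in the shown numbers points to a direction. The estimate for compound 3 therefore stays close to compound 2, with a wide range, and is expected to be 9000 nM in this assay, between 2000 nM and 40000 nM. This estimate means an expected step of a 2.0-fold higher number from compound 2 to compound 3 (0.30 log units; within the scatter), which may turn out in either direction.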

Compound 3, half-maximal inhibitory concentration: "not active" (no number reported)
For compound 3 the study gives words and no number; no gap can be computed for the estimate.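

Within the data shown here, compound 3 is reported only in words as "not active" in this assay, without a number, so no step from compound 2 to compound 3 can be read. The compounds shown leave open how large any difference between benzyl and hydrogen on that aromatic nitrogen is. Nothing shown offers an explanation for this result.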